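The source may report more compounds than this note shows. Statements on the series, on what has been measured and on what is new or still open speak of the compounds shown alone.

Working notes on the series. Compound 3 `Cc1ccc2nc(Cl)c(/C=C/C(=O)c3cc(C)sc3C)cc2c1` gives the highest of the three numbers in a functional assay on HUVEC cells (Homo sapiens), read by BrdU incorporation, with a stated time of 72 h (on this read-out lower numbers stand for stronger inhibition and higher numbers for weaker inhibition), with 229 nM. Its nearest neighbour is compound 1 `Cc1ccc2nc(Cl)c(/C=C/C(=O)c3ccc(I)s3)cc2c1`, which in this assay gives 129 nM; the gap is a 1.8-fold higher number from compound 1 to compound 3 (0.25 log units; within the scatter). The furthest is compound 2 `Cc1ccc2nc(Cl)c(/C=C/C(=O)c3sccc3Cl)cc2c1`, which in this assay gives 37.5 nM; that gap is a 6.1-fold higher number from compound 2 to compound 3 (0.79 log units; beyond the scatter). Between compound 1 and compound 2 the change on the carbonyl carbon gave a 3.4-fold lower number from compound 1 to compound 2 (0.54 log units; beyond the scatter).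

Compound 4 `Cc1ccc2nc(Cl)c(/C=C/C(=O)c3sccc3Br)cc2c1` is not yet measured. Its change from compound 3 is 3-bromothiophen-2-yl in place of 2,5-dimethylthiophen-3-yl on a carbonyl carbon. Among the compounds with values here, the step that bears on it most directly is the reverse of the one from compound 2 to compound 3, where a 3-chlorothiophen-2-yl gave a 6.1-fold higher number from compound 2 to compound 3 (0.79 log units; beyond the scatter); no measured pair isolates bromine against chlorine on the thiophene, so that part is unsupported. A lower number for compound 4 in this assay is therefore expected, by a step of about a 5.1-fold lower number from compound 3 to compound 4 (0.71 log units; beyond the scatter). The estimate for compound 4 is 45 nM, within 18 nM to 110 nM.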

Compound 4, half-maximal inhibitory concentration: 61.9 nM
For compound 4 the middle estimate is 1.4-fold (0.14 log units) below the measured one; the measured number falls inside the stated range.
By their numbers in this assay, from the lowest: compounds 2 and 4 (each within the scatter of the next); then compounds 1 and 3 (each within the scatter of the next).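

In this assay, within the data shown here, the pair of compounds 2 and 4 isolates the halogen for the first time: bromo in place of chloro on an aromatic carbon gives a 1.7-fold higher number from compound 2 to compound 4 (0.22 log units; within the scatter) and so does not separate the two groups. The 3-bromothiophen-2-yl also stands apart from the other two groups on the carbonyl carbon, with a 3.7-fold lower number from compound 3 to compound 4 (0.57 log units; beyond the scatter) against 2,5-dimethylthiophen-3-yl and a 2.1-fold lower number from compound 1 to compound 4 (0.32 log units; beyond the scatter) against 5-iodothiophen-2-yl, so the low numbers are no longer confined to the 3-chlorothiophen-2-yl of compound 2. No measurement in hand bears on why these groups differ.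

Open, on these data alone, is whether a halogen is required at all, which a 3-methylthiophen-2-yl or a plain thiophen-2-yl on the carbonyl carbon would test. Also open, as far as these compounds go, is whether a phenyl can replace the thiophene, or an amine can be carried on it.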